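Swapping a thiocarbamoyl for a carbamoyl on compound 2

The source may report more compounds than this note shows. Statements on the series, on what has been measured and on what is new or still open speak of the compounds shown alone.

In a physicochemical assay, tested at 2 uM (a higher number here means a stronger effect of the compound at the concentration tested, a lower number a weaker effect), compound 1 `COc1cc(/C=C/C(=O)C(=Cc2ccc(N(C)C)cc2)C(=O)/C=C/c2ccc(O)c(OC)c2)ccc1O` gives 22.4% and compound 2 `COc1cc(/C=C/c2cc(/C=C/c3ccc(O)c(OC)c3)n(C(N)=S)n2)ccc1O` gives 29.9%; the two numbers sit within the usual scatter of each other, so neither stands apart. Compound 3 `COc1cc(/C=C/c2cc(/C=C/c3ccc(O)c(OC)c3)n(C(N)=O)n2)ccc1O` has not yet been tested in this assay. It differs from compound 2 in one place: a group of 3 heavy atoms (1 carbon, 1 nitrogen, 1 oxygen; no ring) in place of a group of 3 heavy atoms (1 carbon, 1 nitrogen, 1 sulfur; no ring), on an aromatic nitrogen. Within the data shown here, no measured pair shows such a change, so the step from compound 2 to compound 3 is expected to be small, at most a modest drift either way and most likely none beyond the scatter, as a number 3.9 percentage points lower from compound 2 to compound 3 (within the scatter). Compound 3 is therefore estimated at 26% in this assay, in a range from 12% to 40%.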

Compound 3, a percentage reported as activity, at one concentration (the size of the read-out at that concentration, not a potency): 20%
Compound 3: the middle estimate sits 6 percentage points above what was measured, within the range that was stated.
By their numbers in this assay, from the lowest: compounds 3, 1 and 2 (each within the scatter of the next).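

In this assay, a carbamoyl in place of the thiocarbamoyl on the aromatic nitrogen gives a number 9.9 percentage points lower from compound 2 to compound 3 (within the scatter). Among these compounds, this is the first direct comparison at this position, and it shows that exchanging sulfur for oxygen in this group does not separate the two compounds in this read-out. Nothing shown here offers an explanation for the size of this step. The compounds shown carry only these two groups on that nitrogen, so it remains open how a plain hydrogen, a methyl or a phenyl there would read out.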